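A Fluorine Added to the Anilide of Compound 2

The source may hold more compounds than are shown below. What is called first, only, known or untested is meant among the compounds shown, and "the series" means these compounds.

Among the compounds with values here, compound 2 `Cc1cc(C(=O)Nc2ccccc2)nn1Cc1cc(Cl)ccc1OCc1ccccc1` is the stronger of the two compounds measured so far. In an assay on CHO-K1 cells for displacement of a labelled ligand from prostaglandin E2 receptor EP1 subtype (Homo sapiens) (a lower number here means a stronger inhibitor, a higher number a weaker inhibitor), compound 2 gives 39.8 nM. The other compound, compound 1 `Cc1cc(C(=O)NC(C)C)nn1Cc1cc(Cl)ccc1OCc1ccccc1`, carries an isopropyl group on the amide nitrogen instead of a phenyl ring, and in this assay compound 1 gives 126 nM. Within the data shown here, that exchange, a 3.2-fold lower number from compound 1 to compound 2 (0.50 log units; beyond the scatter), is the only step recorded, and it concerns the whole amide substituent rather than a small addition to it. Compound 3 `Cc1cc(C(=O)Nc2cccc(F)c2)nn1Cc1cc(Cl)ccc1OCc1ccccc1` differs from compound 2 by fluoro in place of hydrogen on an aromatic carbon. Among the measured compounds shown here, no measured pair shows what such an addition to the phenyl ring does here, so the recorded step offers no direct guide. For compound 3 a change no larger than the usual scatter is expected, a 1.1-fold lower number from compound 2 to compound 3 (0.06 log units; within the scatter). Compound 3 is therefore estimated at 35 nM in this assay, with a likely range from 15 nM to 90 nM.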

Compound 3, half-maximal inhibitory concentration: 200 nM
Estimate against measurement, compound 3: 5.7-fold (0.76 log units) below, and the stated range ends below it.
By their numbers in this assay, from the lowest: compound 2; then compounds 1 and 3 (each within the scatter of the next).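

Even the smallest addition to the anilide ring matters at this position: fluoro in place of hydrogen on an aromatic carbon gives a 5.0-fold higher number from compound 2 to compound 3 (0.70 log units; beyond the scatter) in this assay, so this ring does not tolerate every change on this carbon. The advantage of phenyl over isopropyl on the amide nitrogen also disappears with this one atom, as 3-fluorophenyl in place of isopropyl gives a 1.6-fold higher number from compound 1 to compound 3 (0.20 log units; within the scatter), which leaves these two compounds indistinguishable in this assay. Nothing available explains why fluoro has this effect here.

The compounds shown carry a substituent on this phenyl ring at only one position, so it remains open whether the weakening belongs to fluoro itself or to its place on the ring. Going by these compounds, it is also open how a different group on the same carbon, such as chloro, methoxy or an amine, would compare.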